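Thiocyanate Analogue With Chloro In Place Of Fluoro

The source may report more compounds than this note shows. Statements on the series, on what has been measured and on what is new or still open speak of the compounds shown alone.

Compound 1 `Clc1ccc(Cc2nn3c(Br)c(-c4ccc(Cl)cc4)nc3s2)cc1` gives > 250000 nM in an ADME assay on CCRF-CEM cells (Homo sapiens) for cytotoxicity, with a stated time of 72 h (a higher number here means a weaker inhibitor, a lower number a stronger inhibitor), which is a limit of the assay, not a number.
Compound 2 `O=Cc1c(-c2ccc(Cl)cc2)nc2sc(Cc3ccc(Cl)cc3)nn12` gives 5800 nM in this assay.
Compound 3 `N#CSc1c(-c2ccc(F)cc2)nc2sc(Cc3ccc(Cl)cc3)nn12` gives 24000 nM in this assay.

Compound 3 thus stands at the highest of the two numbers, with compound 2 nearest. Among the compounds with values here, the only measured step, an at least 43-fold lower number from compound 1 to compound 2 (1.63 log units; beyond the scatter), concerns a different position and is bounded by the limit of > 250000 nM in this assay, at which 1 of the 3 values shown sits. Compound 4 `N#CSc1c(-c2ccc(Cl)cc2)nc2sc(Cc3ccc(Cl)cc3)nn12` differs from compound 3 by chloro in place of fluoro on an aromatic carbon. Within the data shown here, no measured step bears on this exchange, so no step beyond the scatter is expected in this assay. For compound 4 the expected value is 16000 nM, between 5000 nM and 60000 nM. The expected step is therefore a 1.5-fold lower number from compound 3 to compound 4 (0.18 log units; within the scatter).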

Compound 4, half-maximal inhibitory concentration: 30000 nM
Compound 4: middle estimate off by 1.9-fold (0.27 log units), on the low side; low and high end bracket the measured number.
By their numbers in this assay, from the lowest: compound 2; then compounds 3 and 4 (each within the scatter of the next). At a limit, above all of these: compound 1.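

With cyanosulfanyl kept, chloro in place of fluoro on the aromatic carbon leaves this assay within the scatter (a 1.3-fold higher number from compound 3 to compound 4 (0.10 log units; within the scatter)). With the chloro kept, cyanosulfanyl in place of formyl gives a higher number (a 5.2-fold higher number from compound 2 to compound 4 (0.71 log units; beyond the scatter)). Cyanosulfanyl in place of bromo gives a lower number (an at least 8.3-fold lower number from compound 1 to compound 4 (0.92 log units; beyond the scatter)), but that step is bounded by a limit and not by a number: the limit of > 250000 nM in this assay, at which 1 of the 4 values shown sits.

The compounds shown leave open how an amine or a carboxylic acid would read on the carbon that carries cyanosulfanyl. As far as these compounds go, whether fluoro and chloro also read alike with formyl or bromo on that carbon remains open too.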